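The compounds below may be only part of what the source reports. "The series", "measured", "known", "first", "only" and "open" are said of these compounds alone.

Measured in a functional assay on DWD cells (Homo sapiens) for inhibition, read by sulforhodamine B assay; on this read-out lower numbers stand for stronger inhibition of growth and higher numbers for weaker inhibition of growth:

- compound 1 `c1ccc(-c2ccc(-c3ccc(-c4nc5ccccc5[nH]4)cc3)cc2)cc1` gives 100000 nM
- compound 2 `Cc1ccc2[nH]c(-c3ccc(-c4ccc(-c5cccc(Cl)c5)cc4)cc3)nc2c1` gives 2510 nM
- compound 3 `Oc1cccc2[nH]c(-c3ccc(-c4ccc(-c5ccccc5)cc4)cc3)nc12` gives 9680 nM

Compound 3 stands in the middle of these three numbers, lower than compound 1 and higher than compound 2. The next compound is compound 4 `COc1ccc(-c2ccc(-c3ccc(-c4nc5c(O)cccc5[nH]4)cc3)cc2)cc1`, which has not yet been measured in this assay. Its structure departs from compound 3 by one change: methoxy in place of hydrogen on an aromatic carbon. In words, this is methoxy in place of hydrogen on an aromatic carbon, and the hydroxy of compound 3 stays in place.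

Among the measured compounds shown here, only one measured step is available, a 10-fold lower number from compound 1 to compound 3 (1.01 log units; beyond the scatter). It is a large step, but it belongs to a different change, hydroxy in place of hydrogen on an aromatic carbon, so it bears on the new change only indirectly. For the measured compounds named here, no measured pair shows what methoxy does here. Compound 2 , at 2510 nM, shows only that a lower number occurs among these compounds, and it differs from compound 3 in more than one place. No step beyond the scatter is therefore expected, and the uncertainty is wide. The expected step is a 1.4-fold lower number from compound 3 to compound 4 (0.14 log units; within the scatter). For compound 4 the estimated value is 7000 nM, with an expected range from 2000 nM to 25000 nM.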

Compound 4, concentration for 50% growth inhibition: 6400 nM
The estimate for compound 4 lay 1.1-fold (0.04 log units) above the measured number; measured number inside the range.
By their numbers in this assay, from the lowest: compound 2; then compounds 4 and 3 (each within the scatter of the next); then compound 1.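

Among the compounds shown here, with the hydroxy of compound 3 held in place, the change from phenyl to 4-methoxyphenyl gives a 1.5-fold lower number from compound 3 to compound 4 (0.18 log units; within the scatter) in this assay and thus gives the first direct reading at this place, para to a large group: methoxy can sit there on the six-membered aromatic ring of carbon only without a step beyond the scatter. The one other single change shown, hydroxy in place of hydrogen on an aromatic carbon, gives a 10-fold lower number from compound 1 to compound 3 (1.01 log units; beyond the scatter) and so moves the number far more than methoxy does here, although that step belongs to a different group at a different place. No supporting evidence bears on this result, so the reading stays a plain observation of the numbers.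

The compounds shown leave open whether methoxy would give the same small step without the hydroxy of compound 3, since the pair read here has that hydroxy on both sides. They also leave open whether an amine, a carboxylic acid or a longer chain such as butoxy at this same place would stay within the scatter or shift the number beyond it.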